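Swapping methoxy for methyl on the ketone ring of compound 1

This account rests on a few compounds, and the source may have more. Where it says the series, first, only, none or still open, it means among the compounds named here.

Measured compounds:
- compound 1 `COc1ccc(C(=O)/C=C/c2cc(-c3ccc(OC)c(OC)c3)n3nc(-c4ccccc4)cc3n2)cc1OC`: 7200 nM
- compound 2 `COc1ccc(-c2cc(/C=C/C(=O)c3ccc(OC)c(OC)c3)nc3cc(-c4ccccc4)nn23)cc1`: 16400 nM
- compound 3 `COc1ccc(/C=C/C(=O)c2cc(-c3cc(OC)c(OC)c(OC)c3)n3nc(-c4ccccc4)cc3n2)cc1OC`: 15300 nM

In a functional assay on DU-145 cells (Homo sapiens) for antiproliferative activity, read by MTT assay, with a stated time of 24 h (a higher number here means a weaker inhibitor, a lower number a stronger inhibitor), compound 1 gives the lowest of the three numbers, 7200 nM. Compound 3 sits a little behind it at 15300 nM, and compound 2 gives 16400 nM, both beyond the usual scatter.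

Compound 4 `COc1ccc(-c2cc(/C=C/C(=O)c3ccc(C)c(C)c3)nc3cc(-c4ccccc4)nn23)cc1OC` differs from compound 1 in one place: 3,4-dimethylphenyl in place of 3,4-dimethoxyphenyl on a carbonyl carbon. Among the measured compounds shown here, no measured pair shows exactly this change. The nearest guide is a 2.3-fold higher number from compound 1 to compound 2 (0.36 log units; beyond the scatter), where removing one methoxy group from the other aromatic ring gave a modest step in the weaker direction. Compound 3 also carries the dimethoxyphenyl on the carbonyl side and gives a number close to compound 2. Trading both oxygen-bearing groups for methyls in compound 4 is a larger change than either of these, so a somewhat larger weakening seems the most likely outcome in this assay, though a number within the scatter of compound 1 cannot be ruled out.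

For compound 4 the estimate is 15000 nM, with a range from 5000 nM to 45000 nM, which is expected to correspond to a 2.1-fold higher number from compound 1 to compound 4 (0.32 log units; beyond the scatter).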

Compound 4, half-maximal inhibitory concentration: 12100 nM
Estimate against measurement, compound 4: 1.2-fold (0.09 log units) above; low and high end bracket the measured number.
By their numbers in this assay, from the lowest: compounds 1, 4, 3 and 2 (each within the scatter of the next, the first and the last beyond it).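

In this assay, putting 3,4-dimethylphenyl in place of 3,4-dimethoxyphenyl on the carbonyl carbon gives a 1.7-fold higher number from compound 1 to compound 4 (0.23 log units; within the scatter) and so leaves compound 4 indistinguishable from compound 1. Among the compounds shown here, this is the first direct test of the aromatic ring on the carbonyl: here both methoxy oxygens can go without a change that exceeds the scatter, whereas losing one methoxy from the other aromatic ring gives a 2.3-fold higher number from compound 1 to compound 2 (0.36 log units; beyond the scatter) and does exceed it. No measurement shown here bears on the reason for this result.

From the compounds shown here alone, it remains open whether this tolerance extends to groups of a different kind on the carbonyl-bound ring, such as a carboxylic acid, a dimethylamino group or a longer alkoxy chain. Also open, going by these compounds, is whether the same methoxy-to-methyl swap would be tolerated on the other aromatic ring.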